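This account rests on a few compounds, and the source may have more. Where it says the series, first, only, none or still open, it means among the compounds named here.

Going by the values given here, compound 1 `Brc1ccc(NC2=NCCC3(CCCCC3)S2)cc1` is the more permeable of the two compounds measured so far. In a physicochemical assay for permeability (on this read-out lower numbers stand for lower permeability and higher numbers for higher permeability), compound 1 gives 90.3 10^-6 cm/s. Among the compounds with values here, compound 2 `NC1=NCCC2(CCCCC2)S1`, which carries no aryl group on the shared core, is the only other measured compound; in this assay compound 2 gives 7.33 10^-6 cm/s, a far lower number than that of compound 1, beyond the usual scatter of the measurement. Compound 3 `Cc1ccc(NC2=NCCC3(CCCCC3)S2)cc1` has not yet been measured. It differs from compound 1 in one place: methyl in place of bromo on an aromatic carbon. Within the data shown here, no measured pair shows what swapping bromo for methyl does in this assay, so the expectation rests on the two numbers alone. Since compound 1 already sits at the high end, the step expected a 1.1-fold lower number from compound 1 to compound 3 (0.05 log units; within the scatter) is small, in no firm direction, and within the scatter. Compound 3 is therefore estimated at 80 10^-6 cm/s, with a likely range from 45 10^-6 cm/s to 140 10^-6 cm/s.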

Compound 3, apparent permeability: 5.67 10^-6 cm/s
For compound 3 the middle estimate is 14-fold (1.15 log units) above the measured one; measured number below the stated range.
By their numbers in this assay, from the lowest: compounds 3 and 2 (each within the scatter of the next); then compound 1.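

In this assay, putting methyl in place of bromo on this aromatic carbon, para to a large group, gives a 16-fold lower number from compound 1 to compound 3 (1.20 log units; beyond the scatter). Going by these compounds alone, this is the first sign that the read-out can respond strongly to a change at this place. The change is large even though each group has one heavy atom, neither has a hydrogen-bond donor or acceptor, and neither carries a net charge. The data at hand offer nothing that accounts for a step of this size.

From the compounds shown here alone, it remains open whether compound 1 or compound 3 is the unusual one, which chloro, methoxy or an amine on the same aromatic carbon could help to settle. It is also unknown whether the same swap would give a similar step on another carbon of this ring.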